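Hexyl in place of vinyl on a deoxyuridine-type core

The source may report more compounds than this note shows. Statements on the series, on what has been measured and on what is new or still open speak of the compounds shown alone.

Compound 1 `C=Cc1cn([C@H]2C[C@H](O)[C@@H](CO)O2)c(=O)[nH]c1=O`: 14200 nM
Compound 2 `C[C@H](O)C1CC(CCn2cnc3c(N)ncnc32)C1(C)C`: > 200000 nM
Compound 3 `Cc1cn(C[C@@H]2C[C@H](CO)c3ccccc32)c(=O)[nH]c1=O`: > 200000 nM

Of the compounds shown here, three have been measured in an ADME assay on L1210/0 cells (Mus musculus) for cytotoxicity, with a stated time of 48 h; a lower number here means a stronger inhibitor, a higher number a weaker inhibitor. Among the compounds with values here, compound 1 gives 14200 nM and is the only compound with a number rather than a limit. Compound 2 reaches only the assay limit, > 200000 nM. Compound 3 likewise reaches only the assay limit, > 200000 nM. Two of the three values therefore sit at the same limit (the limit of > 200000 nM in this assay, at which 2 of the 3 values shown sit), so compound 1 stands alone with a measured number.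

Compound 4 `CCCCCCc1cn([C@H]2C[C@H](O)[C@@H](CO)O2)c(=O)[nH]c1=O` differs from compound 1 in one place: hexyl in place of vinyl on an aromatic carbon. Within the data shown here, no step between two measured compounds is available to calibrate this change, so the expectation rests on compound 1 alone. Compound 4 is expected to be a weaker inhibitor than compound 1, with the step of a 3.5-fold higher number from compound 1 to compound 4 (0.55 log units; beyond the scatter) expected to lie beyond the scatter. The estimate for compound 4 in this assay is 50000 nM, with a range from 10000 nM to 200000 nM.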

Compound 4, half-maximal inhibitory concentration: > 200000 nM
Compound 4 was reported as a limit; the forecaster's own chance of this, stated with the estimate: 25%; at least 4.0-fold (0.60 log units) between middle value and limit.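

In this assay compound 4 reaches only a limit, > 200000 nM, and not a number. Hexyl in place of vinyl on this aromatic carbon, two atoms from the ring nitrogen, therefore gives an at least 14-fold higher number from compound 1 to compound 4 (1.14 log units; beyond the scatter), so the group at this one position is enough to separate a measured value from the limit on the shared core. The true size of this step remains unknown, and compound 1 is now the only compound with a number: the limit of > 200000 nM in this assay, at which 3 of the 4 values shown sit.

The compounds shown leave open whether the chain length or the loss of the double bond carries the step, as hexyl differs from vinyl in both. An ethyl group, a longer chain that keeps its double bond, or a hexyl chain ending in an amine or a carboxylic acid would each bear on that question.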